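The source may hold more compounds than are shown below. What is called first, only, known or untested is meant among the compounds shown, and "the series" means these compounds.

In a functional assay on MCF7 cells (Homo sapiens) for antiproliferative activity, read by sulforhodamine B assay, with a stated time of 48 h (a higher number here means a weaker inhibitor, a lower number a stronger inhibitor), compound 1 `O=C1NCCN1c1ccc(S(=O)(=O)Nc2ccc3[nH]ccc3c2)cc1` gives 170 nM and compound 2 `Cc1ccc(NS(=O)(=O)c2ccc(N3CCNC3=O)cc2)cc1` gives 610 nM which is the higher of the two numbers and so marks the weaker inhibitor. Compound 3 `O=C1NCCN1c1ccc(S(=O)(=O)Nc2ccc(I)cc2)cc1` differs from compound 2 in one place (iodo in place of methyl on an aromatic carbon): iodo in place of methyl on an aromatic carbon, para to a large group. Within the data shown here, no measured pair shows this change, and the expectation in this assay is for no step beyond the scatter. The expected step is a small one (a 1.2-fold lower number from compound 2 to compound 3 (0.09 log units; within the scatter)). For compound 3 the estimated value is 500 nM (range 170 nM to 1500 nM).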

Compound 3, half-maximal inhibitory concentration: 600 nM
The estimate for compound 3 lay 1.2-fold (0.08 log units) below the measured number; the measured number falls inside the stated range.
By their numbers in this assay, from the lowest: compound 1; then compounds 3 and 2 (each within the scatter of the next).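

In this assay, putting iodo in place of methyl on this aromatic carbon, para to a large group, gives a 1.0-fold lower number from compound 2 to compound 3 (0.01 log units; within the scatter), so compound 2 and compound 3 read alike. Among these compounds, this is the first step that isolates a single change at this place, and it shows that these two groups cannot be told apart here.

From the compounds shown here alone, how an amine, a carboxylic acid or a longer chain at this place would read remains open. Nothing given here accounts for the match between methyl and iodo.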